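Removing the fluoro from the fused ring of compound 2

The compounds below may be only part of what the source reports. "The series", "measured", "known", "first", "only" and "open" are said of these compounds alone.

Measured compounds:
compound 1 `Fc1ccc2nc(NCCCCN3CCN(c4cccc(Cl)c4Cl)CC3)nc(NCc3ccco3)c2c1` — 390 nM
compound 2 `Cc1cccc(N2CCN(CCCCNc3nc(NCc4ccco4)c4cc(F)ccc4n3)CC2)c1C` — 1830 nM
compound 3 `COc1ccc(Nc2nc(NCc3ccco3)c3cc(F)ccc3n2)cc1` — 4340 nM

In a functional assay on HT-29 cells (Homo sapiens) for cytotoxicity, read by MTT assay, with a stated time of 2 days (on this read-out lower numbers stand for stronger inhibition and higher numbers for weaker inhibition), compound 2 gives 1830 nM, the second highest of the three numbers. Compound 1 gives 390 nM, the lowest of the set, and compound 3 gives 4340 nM, the highest; compound 2 sits nearer to compound 3 than to compound 1. Among the compounds with values here, the only step between two compounds that differ in a single place is a 4.7-fold higher number from compound 1 to compound 2 (0.67 log units; beyond the scatter), and it concerns the group on the amine nitrogen in a ring, not the fused ring.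

Compound 4 `Cc1cccc(N2CCN(CCCCNc3nc(NCc4ccco4)c4ccccc4n3)CC2)c1C` differs from compound 2 by hydrogen in place of fluoro on an aromatic carbon. Within the data shown here, no measured step bears on this position: all three measured compounds carry the fluoro on the fused ring, so the series gives no reading of what its removal does in this assay. With nothing to point either way, the working expectation is no step beyond the scatter, with a wide range to cover the lack of a precedent. Compound 4 is therefore expected to give about 1800 nM, between 600 nM and 5400 nM. The expected step is a 1.0-fold lower number from compound 2 to compound 4 (0.01 log units; within the scatter).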

Compound 4, half-maximal inhibitory concentration: 860 nM
For compound 4 the middle estimate is 2.1-fold (0.32 log units) above the measured one; the measured number falls inside the stated range.
By their numbers in this assay, from the lowest: compound 1; then compound 4; then compound 2; then compound 3.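

In this assay, the position on the fused ring now has its first reading: a 2.1-fold lower number from compound 2 to compound 4 (0.33 log units; beyond the scatter). This step is modest but beyond the scatter, and it runs towards stronger inhibition when hydrogen replaces fluoro, so the fluoro on this aromatic carbon is not required for the activity of the 2,3-dimethylphenyl compound. The change removes one fluorine atom and adds no ring, hydrogen-bond donor, hydrogen-bond acceptor or net charge, yet no measurement at hand accounts for the step.

This single pair leaves open whether the same step appears with 2,3-dichlorophenyl on the amine nitrogen in the ring, the group carried by compound 1, or whether the reading is confined to the 2,3-dimethylphenyl background of compound 2 and compound 4. Also open, as far as these compounds go, is how a nitrile or a trifluoromethyl on the same aromatic carbon would compare with fluoro and hydrogen, which would show whether this position responds to groups other than these two.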